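A Formyl Group Replaces Methoxy on a Biaryl Imidazopyrazine

The compounds below may be only part of what the source reports. "The series", "measured", "known", "first", "only" and "open" are said of these compounds alone.

Measured compounds:
- Compound 1, `Brc1cn2ccnc2c(-c2ccc3ncn(C4CCCCC4)c3c2)n1`, gives 37.6% in a functional assay on UO-31 cells (Homo sapiens) for inhibition, read by sulforhodamine B assay, with a stated time of 48 h, tested at 10 uM; a higher number here means more inhibition at the concentration tested (going by the name of the read-out), a lower number less inhibition.
- Compound 2, `c1ccc(-c2cn3ccnc3c(-c3ccc4ncn(C5CCCCC5)c4c3)n2)cc1`, gives 55.2%.
- Compound 3, `COc1ccc(-c2cn3ccnc3c(-c3ccc4ncn(C5CCCCC5)c4c3)n2)cc1`, gives 61.5%.

Among these three numbers compound 3 stands highest, but its lead over compound 2 is within the scatter of this assay; only the gap to compound 1 is real. The two real steps both come from the same change of kind: a phenyl ring in place of bromo, a number 17.6 percentage points higher from compound 1 to compound 2 (beyond the scatter), and a 4-methoxyphenyl in place of bromo, a number 23.9 percentage points higher from compound 1 to compound 3 (beyond the scatter). Putting methoxy onto the phenyl ring, a number 6.3 percentage points higher from compound 2 to compound 3 (within the scatter), adds nothing that can be trusted.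

Compound 4, `O=Cc1ccc(-c2cn3ccnc3c(-c3ccc4ncn(C5CCCCC5)c4c3)n2)cc1`, has not been measured. It differs from compound 3 in one place: formyl in place of methoxy on an aromatic carbon. Going by the values given here, the only step that bears on this change is the one from compound 2 to compound 3, which was within the scatter, so swapping the methoxy for another small group on the same ring is expected to leave the number about where the phenyl compounds already sit. The expected step is therefore small and within the scatter, a number 6.5 percentage points lower from compound 3 to compound 4 (within the scatter). For compound 4 the estimate is 55%, with a range from 40% to 70%.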

Compound 4, a percentage reported as inhibition, at one concentration (the size of the read-out at that concentration, not a potency): 82.2%
Compound 4: the middle estimate sits 27.2 percentage points below what was measured; measured number outside the range, above it.
By their numbers in this assay, from the lowest: compound 1; then compounds 2 and 3 (each within the scatter of the next); then compound 4.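

In this assay the group on the aromatic carbon para to a large group clearly matters: with formyl in place of methoxy, the result is a number 20.7 percentage points higher from compound 3 to compound 4 (beyond the scatter), even though the swap leaves the heavy-atom and hydrogen-bond acceptor counts unchanged and adds one double bond outside aromatic rings. Adding formyl to the bare phenyl ring gives a number 27 percentage points higher from compound 2 to compound 4 (beyond the scatter), whereas methoxy at this position gave only a number 6.3 percentage points higher from compound 2 to compound 3 (within the scatter), so a substituent here can move the number well beyond the scatter, and the outcome depends on which group is used; replacing bromo with the whole 4-formylphenyl group gives a number 44.6 percentage points higher from compound 1 to compound 4 (beyond the scatter), the largest step in this set. Nothing available here accounts for why formyl behaves so differently from methoxy.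

Still open, going by these compounds, is whether the gain belongs to formyl alone or would also appear with a related group at this position, such as a carboxylic acid, a nitrile or an amide. Also open, on these data alone, is how compound 4 would behave across a range of concentrations, since this assay reports the size of inhibition at a single concentration and not a potency.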